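The source may report more compounds than this note shows. Statements on the series, on what has been measured and on what is new or still open speak of the compounds shown alone.

Of the compounds shown here, three sharing one core have been measured in a functional assay on HT-29 cells (Homo sapiens) for inhibition, read by CellTiter-Glo, with a stated time of 72 h (a higher number here means that more compound is tolerated, a lower number that less compound is tolerated), and they differ only in the group on an amine nitrogen. Compound 1 `CC1=C(CC(=O)N(C)CCN(C)C(=O)[C@@H](N)C(C)C)c2cc(F)ccc2/C1=C\c1ccc([S+](C)[O-])cc1` carries (1-amino-2-methylpropyl)carbonyl there and gives 30200 nM as its number. Compound 2 `CC1=C(CC(=O)N(C)CCN(C)S(C)(=O)=O)c2cc(F)ccc2/C1=C\c1ccc([S+](C)[O-])cc1` carries methylsulfonyl and gives 12400 nM in the same test. Compound 3 `CC1=C(CC(=O)N(C)CCN(C)S(=O)(=O)c2ccccc2)c2cc(F)ccc2/C1=C\c1ccc([S+](C)[O-])cc1` carries phenylsulfonyl and gives 6090 nM as the lowest of the three numbers. Compound 4 `CC1=C(CC(=O)N(C)CCN(C)S(=O)(=O)c2ccc(C)cc2)c2cc(F)ccc2/C1=C\c1ccc([S+](C)[O-])cc1` makes one small change to compound 3: methyl in place of hydrogen on an aromatic carbon with methyl in place of hydrogen on an aromatic carbon, which turns phenylsulfonyl into (4-methylphenyl)sulfonyl.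

The nearest guide is the step of a 2.0-fold lower number from compound 2 to compound 3 (0.31 log units; beyond the scatter) where phenyl replaced methyl on the sulfonyl sulfur. The larger swaps gave a 2.4-fold lower number from compound 1 to compound 2 (0.39 log units; beyond the scatter) and a 5.0-fold lower number from compound 1 to compound 3 (0.70 log units; beyond the scatter) and all three steps were modest. None of them alters the phenyl group itself, so this exact change has no direct measurement behind it. Adding one methyl is a smaller edit than any of those, so in this assay no step beyond the scatter is expected, with perhaps a slight lean towards a lower number. The estimated step is a 1.2-fold lower number from compound 3 to compound 4 (0.09 log units; within the scatter) and it stays small. For compound 4 the expected value is 5000 nM with an estimated range from 2500 nM to 10000 nM in this test.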

Compound 4, half-maximal cytotoxic concentration: 6180 nM
Beside the measured number, compound 4's estimate is 1.2-fold (0.09 log units) below it, and the stated range covers the measured number.
By their numbers in this assay, from the lowest: compounds 3, 4 and 2 (each within the scatter of the next, the first and the last beyond it); then compound 1.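

In this assay, placing a methyl on an aromatic carbon, para to a large group, gives a 1.0-fold higher number from compound 3 to compound 4 (0.01 log units; within the scatter) and so the phenyl and 4-methylphenyl versions of the sulfonyl group cannot be told apart in this test. Among these compounds, none of the earlier compounds altered the phenyl group itself, and this single added carbon is the first sign that a small change at this position can pass without a step beyond the scatter. Against the other two groups, the picture is mixed: a 4.9-fold lower number from compound 1 to compound 4 (0.69 log units; beyond the scatter) is a modest step, much like the one to compound 3, whereas a 2.0-fold lower number from compound 2 to compound 4 (0.30 log units; within the scatter) is printed as within the scatter, which places the gap between the methylsulfonyl group and either aromatic sulfonyl group right at the edge of what this test can resolve.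

Nothing given here offers an explanation for this result. A single methyl says little about other groups at the same position, such as a methoxy group, a chlorine atom, an amine or a carboxylic acid, or about a methyl on another carbon of the same ring.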